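Solubility notes: trifluoromethyl for methyl on compound 3

The compounds below may be only part of what the source reports. "The series", "measured", "known", "first", "only" and "open" are said of these compounds alone.

Measured so far:
Compound 1, `CCc1cnc(N2CCC(n3nnc4cc(-c5ccc(S(C)(=O)=O)cc5)ccc43)CC2)nc1`, gives only a limit in a physicochemical assay for solubility, read by HPLC, in phosphate buffer, measured as thermodynamic solubility, with a stated time of 24 h, at pH 6.8 (a higher number here means a more soluble compound, a lower number a less soluble compound), namely < 130 nM; see (the limit of < 130 nM in this assay, at which 1 of the 3 values shown sits).
Compound 2, `CCNC(=O)c1ccc(-c2cc3nnn(C4CCN(c5ncc(CC)cn5)CC4)c3cn2)c(Cl)c1`, gives 240 nM in this assay.
Compound 3, `CCNC(=O)c1ccc(-c2cc3nnn(C4CCN(c5ncc(CC)cn5)CC4)c3cn2)cc1C`, gives 1790 nM in this assay.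

Of the two numbers shown, compound 3 has the higher one; compound 2 sits well beneath it, a gap that lies beyond the scatter. Among the compounds with values here, no pair of measured compounds differs in a single place, so no measured step is available for this series.

Compound 4, `CCNC(=O)c1ccc(-c2cc3nnn(C4CCN(c5ncc(CC)cn5)CC4)c3cn2)cc1C(F)(F)F`, is not yet measured. It differs from compound 3 by trifluoromethyl in place of methyl on an aromatic carbon. Within the data shown here, with no measured step of this kind to lean on, the expectation for this assay is a drop from compound 3 to compound 4 of about a 3.0-fold lower number from compound 3 to compound 4 (0.47 log units; beyond the scatter), which would still leave compound 4 above the limit at which compound 1 sits. Compound 4 is therefore estimated at 600 nM, with a plausible range from 150 nM to 2500 nM.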

Compound 4, solubility: 510 nM
Compound 4: the middle estimate sits 1.2-fold (0.07 log units) above what was measured; measured number inside the range.
By their numbers in this assay, from the lowest: compound 2; then compound 4; then compound 3. At a limit, below all of these: compound 1.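

On the aromatic carbon ortho to an ethylcarbamoyl group, the choice of substituent registers in this assay: trifluoromethyl in place of methyl gives a 3.5-fold lower number from compound 3 to compound 4 (0.55 log units; beyond the scatter). Within the data shown here, this is the first change that can be read in a single place, so this position now has a measured effect on the read-out, one that lies beyond the usual scatter. No measurement shown gives a cause for this step.

Among these compounds, with methyl and trifluoromethyl as the only two groups compared here, it remains open how other groups at this carbon, such as an amine, a carboxylic acid or a methoxy group, would read in this assay. As far as these compounds go, whether the same exchange would give a step of similar size and direction on a different core, such as that of compound 1, also remains open.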